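Hydroxy for methyl on the shared core: compound 3

The source may report more compounds than this note shows. Statements on the series, on what has been measured and on what is new or still open speak of the compounds shown alone.

Measured compounds:
compound 1 `Cc1c(OCCCCOc2ccc(C(=O)O)cc2F)ccc(C(=O)CC(C)C)c1O` gives 67.7%
compound 2 `Cc1c(OCCCCOc2ccc(C(=O)O)cc2)ccc(C(=O)CC(C)C)c1C` gives 16.6%

The account follows a single step. In an assay on HEK293 cells for positive allosteric modulation of metabotropic glutamate receptor 3 (Rattus norvegicus), read by thallium flux, with a stated time of 2.5 min (on this read-out lower numbers stand for smaller maximal responses and higher numbers for larger maximal responses), compound 2 stands lowest of the two numbers; its nearest neighbour is compound 1, whose value lies higher by a gap beyond the usual scatter. Compound 1 and compound 2 differ in more than one place, so their two values are noted side by side without a step being drawn between them.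

Compound 3 `Cc1c(OCCCCOc2ccc(C(=O)O)cc2)ccc(C(=O)CC(C)C)c1O` has not been measured. It differs from compound 2 by hydroxy in place of methyl on an aromatic carbon. Among the compounds with values here, no step between measured compounds is available for this change on its own. Compound 1, which also carries the hydroxy group on the shared core, gives 67.7%, and that is the nearest guide. On that basis a rise from compound 2 is expected, estimated as a number 33.4 percentage points higher from compound 2 to compound 3 (beyond the scatter), beyond the scatter and in the direction of compound 1. For compound 3 the maximal response in this assay is expected to be about 50%, with a likely range from 25% to 75%.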

Compound 3, largest response reached (reported as percent of maximum), in percent of the reference or control that the assay uses: 51.9%
The estimate for compound 3 lay 1.9 percentage points below the measured number; the range from low to high includes it.
By their numbers in this assay, from the lowest: compound 2; then compound 3; then compound 1.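

In this assay, hydroxy in place of methyl on the aromatic carbon of the shared core, ortho to a methyl group and ortho to an isobutylcarbonyl group, gives a number 35.3 percentage points higher from compound 2 to compound 3 (beyond the scatter), and this is the change read on its own, with nothing else altered. The earlier pair could not show this, since compound 1 and compound 2 differ in more than one place and their gap could not be assigned to either difference. Compound 3 now connects them through two single-place steps: hydrogen in place of fluoro on an aromatic carbon gives a number 15.8 percentage points lower from compound 1 to compound 3 (beyond the scatter), so the fluoro group also bears on the maximal response, though this step is modest where the hydroxy step is large.

The compounds shown leave open how a methoxy group, an amine or a chloro group would fare at the place now held by hydroxy, and whether the fluoro step would look the same on the core that carries methyl rather than hydroxy. No measurement here gives a reason for either step.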